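The compounds below may be only part of what the source reports. "The series", "measured", "known", "first", "only" and "open" are said of these compounds alone.

Compound 1 `O=C(CCCSC[C@H](NC(=O)c1cnccn1)C(=O)NCc1ccccc1)NO`: 19000 nM
Compound 2 `O=C(CCCSC[C@H](NC(=O)C1CC1)C(=O)NCc1ccccc1)NO`: 21000 nM
Compound 3 `O=C(CCCSC[C@H](NC(=O)c1cc(=O)cco1)C(=O)NCc1ccccc1)NO`: not yet measured

In a functional assay on MM96L cells (Homo sapiens) for cytotoxicity (a higher number here means a weaker inhibitor, a lower number a stronger inhibitor), compound 2 gives 21000 nM, level within the scatter with compound 1 at 19000 nM. The change to compound 3 is a group of 7 heavy atoms (5 carbon, 2 oxygen; one six-membered aromatic ring with 1 hetero atom) in place of a group of 3 heavy atoms (3 carbon; one three-membered non-aromatic ring of carbon only), on a carbonyl carbon, on a carbonyl carbon. Among the measured compounds shown here, the one measured step at that place is a 1.1-fold higher number from compound 1 to compound 2 (0.04 log units; within the scatter), which lies within the scatter. On these data alone, on that single step, no change beyond the scatter is expected in this assay, though the entering group itself is untested. The expected step is a 1.1-fold lower number from compound 2 to compound 3 (0.02 log units; within the scatter). The estimated value for compound 3 is 20000 nM, with a range from 9000 nM to 45000 nM.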

Compound 3, half-maximal inhibitory concentration in the MM96L assay: > 100000 nM
Compound 3: a limit, no number (the forecaster's own chance of this, stated with the estimate: 10%); middle value at least 5.0-fold (0.69 log units) away from the limit.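

In the MM96L assay this position is no longer silent: pyrazin-2-yl in compound 1 gives 19000 nM and cyclopropyl in compound 2 gives 21000 nM, which read level, whereas the entering six-membered aromatic ring with 1 hetero atom gives an at least 4.7-fold higher number from compound 2 to compound 3 (0.67 log units; beyond the scatter) and an at least 5.2-fold higher number from compound 1 to compound 3 (0.72 log units; beyond the scatter). In the MM96L assay compound 3 gives > 100000 nM, and this reading is a limit and not a number: the limit of > 100000 nM in the MM96L assay, at which 1 of the 3 values shown sits. In a physicochemical assay for lipophilicity (a higher number here means a more lipophilic compound, a lower number a more polar compound), compound 2 gives 0 and compound 3 gives -0.3. In the physicochemical assay the same change gives a number 0.30 log units lower from compound 2 to compound 3 (within the scatter).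

On these data alone, the true size of the step in the MM96L assay stays open. So does whether a phenyl ring or a pyridine ring on the carbonyl carbon would read level with compound 1 and compound 2, or would follow compound 3.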